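This account rests on a few compounds, and the source may have more. Where it says the series, first, only, none or still open, it means among the compounds named here.

Compound 2 `CCC(=O)NCc1ccc(F)c(OC)c1` gives 2880 nM in an assay on isolated protein for agonist activity at melatonin receptor type 1C (Xenopus laevis), read by spectrophotometry; a lower number here means that less compound is needed, a higher number that more compound is needed for the effect; compound 1 `COc1cc(CNC(C)=O)ccc1F` gives 2090 nM in this assay, and the two values lie within the scatter of each other, as a 1.4-fold higher number from compound 1 to compound 2 (0.14 log units; within the scatter) shows. Compound 3 `CCCC(=O)NCc1ccc(F)c(OC)c1` carries the change methyl in place of hydrogen on a saturated chain carbon, two bonds along the chain from a carbonyl carbon relative to compound 2, a second lengthening of the same acyl chain. For the measured compounds named here, the only step that bears on it, a 1.4-fold higher number from compound 1 to compound 2 (0.14 log units; within the scatter), was a comparable lengthening and stayed within the scatter, so no step beyond the scatter is expected in this assay. Compound 3 is therefore estimated at 3500 nM, within 1500 nM to 8000 nM, a change of a 1.2-fold higher number from compound 2 to compound 3 (0.08 log units; within the scatter).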

Compound 3, half-maximal effective concentration: 2510 nM
Compound 3: the middle estimate sits 1.4-fold (0.14 log units) above what was measured; the range from low to high includes it.
By their numbers in this assay, from the lowest: compounds 1, 3 and 2 (each within the scatter of the next).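

The second methyl, two bonds along the chain from a carbonyl carbon, leaves the number in this assay within the scatter (a 1.1-fold lower number from compound 2 to compound 3 (0.06 log units; within the scatter)). Taken over both lengthenings of the chain together, the number also stays within the scatter (a 1.2-fold higher number from compound 1 to compound 3 (0.08 log units; within the scatter)), so the values remain level across the propanoyl and propylcarbonyl chains as well. Nothing available explains this result. From the compounds shown here alone, whether a longer chain such as pentanoyl, or an amine at the chain end, would stay within the scatter remains open.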